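Replacing the phenylsulfonyl of compound 3 with benzoyl

This account rests on a few compounds, and the source may have more. Where it says the series, first, only, none or still open, it means among the compounds named here.

Of the compounds shown here, three sharing one core have been measured in a functional assay on CAKI-1 cells (Homo sapiens) for inhibition, read by sulforhodamine B assay, with a stated time of 48 h; on this read-out higher numbers stand for weaker inhibition of growth and lower numbers for stronger inhibition of growth. Compound 1 `CC(=O)/C(=C\c1c(-c2ccccc2)[nH]c2ccccc12)S(=O)(=O)c1ccccc1` gives 2400 nM, compound 2 `O=C(/C(=C\c1c(-c2ccccc2)[nH]c2ccccc12)S(=O)(=O)c1ccccc1)c1ccccc1` gives 3100 nM, and compound 3 `N#C/C(=C\c1c(-c2ccccc2)[nH]c2ccccc12)S(=O)(=O)c1ccccc1` gives 5500 nM. For the measured compounds named here, compound 3 thus stands at the highest of the three numbers, though its step of a 1.8-fold higher number from compound 2 to compound 3 (0.25 log units; within the scatter) is within the scatter and only the step of a 2.3-fold higher number from compound 1 to compound 3 (0.36 log units; beyond the scatter) is beyond it; the step of a 1.3-fold higher number from compound 1 to compound 2 (0.11 log units; within the scatter) is also within the scatter. Compound 4 `N#C/C(=C\c1c(-c2ccccc2)[nH]c2ccccc12)C(=O)c1ccccc1` differs from compound 3 by benzoyl in place of phenylsulfonyl on a double-bonded chain carbon bound to a double-bonded chain carbon and a triple-bonded carbon. Going by the values given here, no measured step swaps a phenylsulfonyl for a benzoyl; the three measured steps all change the other substituent on that chain carbon while the phenylsulfonyl stays, and each of them moved this assay by at most a modest amount. On that basis compound 4 is expected to show no step beyond the scatter, a 1.2-fold lower number from compound 3 to compound 4 (0.09 log units; within the scatter). The estimate for compound 4 in this assay is 4500 nM, with a range from 1500 nM to 13000 nM.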

Compound 4, concentration for 50% growth inhibition: 2500 nM
For compound 4 the middle estimate is 1.8-fold (0.26 log units) above the measured one, and the stated range covers the measured number.
By their numbers in this assay, from the lowest: compounds 1, 4, 2 and 3 (each within the scatter of the next, the first and the last beyond it).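

In this assay, for the compounds shown here, the step of a 2.2-fold lower number from compound 3 to compound 4 (0.34 log units; beyond the scatter) is the first measured change to the phenylsulfonyl itself, on a double-bonded chain carbon bound to a double-bonded chain carbon and a triple-bonded carbon. The earlier compounds shown here all kept that group and varied only its partner on the chain, whereas this modest step shows that the phenylsulfonyl is not required for growth inhibition, since benzoyl in its place gives stronger inhibition with the cyano kept. Nothing available here accounts for the direction of this shift.

The compounds shown leave open whether the same swap would hold with acetyl or benzoyl rather than cyano as the partner group. They also leave open how a simple amine, a carboxylic acid or a methylsulfonyl group would behave at this position.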